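A Methyl Added to the Ring of Compound 1

The source may hold more compounds than are shown below. What is called first, only, known or untested is meant among the compounds shown, and "the series" means these compounds.

Compound 1 `N/C(=N\NC(=S)N1CCCCC1)c1ccccn1` gives 86% in a functional assay on HeLa cells (Homo sapiens) for cytotoxicity, read by MTT assay, with a stated time of 72 h, tested at 100 uM; a higher number here means more inhibition of growth at the concentration tested, a lower number less inhibition of growth.
Compound 2 `Cc1cccc(/C(N)=N/NC(=S)N2CCCC2)n1` gives 80.1% in this assay.
Compound 3 `N/C(=N\NC(=S)N1CCCC1)c1ccccn1` gives 89.1% in this assay.

Compound 1 and compound 3 share a core and differ in one place: piperidin-1-yl in place of pyrrolidin-1-yl on a thiocarbonyl carbon. The step of a number 3.1 percentage points higher from compound 1 to compound 3 (within the scatter) is small. Compound 2 is built from compound 3 by a single change: methyl in place of hydrogen on an aromatic carbon. This gave a number 9 percentage points lower from compound 3 to compound 2 (within the scatter), again a small step.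

Compound 4 `Cc1ccnc(/C(N)=N/NC(=S)N2CCCCC2)c1` has not yet been measured. It is built from compound 1 by methyl in place of hydrogen on an aromatic carbon. This is the same kind of change as that from compound 3 to compound 2, but not the same: in compound 2 the methyl sits next to the ring nitrogen, while in compound 4 it sits opposite the ring nitrogen, both meta to a large group.

For compound 4 the expected step is a number 6 percentage points lower from compound 1 to compound 4 (within the scatter), because the earlier methyl addition gave a number 9 percentage points lower from compound 3 to compound 2 (within the scatter) and stayed within the scatter. Compound 4 is therefore estimated at 80%, with a likely range from 62% to 92%.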

Compound 4, percent growth inhibition at one concentration: 70.8%
The estimate for compound 4 lay 9.2 percentage points above the measured number; measured number inside the range.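

In this assay, methyl in place of hydrogen on an aromatic carbon gave a number 15.2 percentage points lower from compound 1 to compound 4 (beyond the scatter). For the compounds shown here, only this step clears the scatter, but the gap between it and the earlier methyl step does not, so the two cores show no detectable difference in how much the change costs: the same change on two cores in this assay, a number 9 percentage points lower (within the scatter) from compound 3 to compound 2 and a number 15.2 percentage points lower (beyond the scatter) from compound 1 to compound 4, 6.2 percentage points apart, within the scatter of two such steps. Going by these compounds alone, this does not make a rule for the series: two pairs are few, and the methyl in compound 4, opposite the ring nitrogen, stands in a different place from the one in compound 2, so the place of the methyl and the core both vary and their contributions cannot be separated.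

The compounds shown leave open whether a methyl opposite the ring nitrogen on the core of compound 3 would give a step like the one seen for compound 4. They also leave open what a longer chain such as ethyl, or an amine, would do at that place in this assay.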